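A few compounds are considered here, and "the series" means these few. Any claim that something is new, unique, unknown or untested is made for them only; others in the source may bear on it.

Measured compounds:
compound 1 `O=C(O)Cc1sc(C(c2ccc(F)cc2)c2ccc(F)cc2)nc1-c1cc(F)cc(F)c1`: 80%
compound 2 `O=C(O)Cc1sc(C(c2ccc(F)cc2)c2ccc(F)cc2)nc1-c1ccco1`: 80%
compound 3 `O=C(O)Cc1sc(C(c2ccc(F)cc2)c2ccc(F)cc2)nc1-c1ccoc1`: 80%

In an in vitro functional assay on HEK285-7 cells for antagonist activity at prostaglandin D2 receptor 2 (Homo sapiens), read by BRET and beta-arrestin recruitment (on this read-out higher numbers stand for larger maximal responses and lower numbers for smaller maximal responses), compound 1 gives 80%. Compound 2 gives 80% in this assay, and compound 3 gives 80%. Compound 3 therefore stands level with both others: the step of no change at the digits printed from compound 1 to compound 3 (within the scatter) and the step of no change at the digits printed from compound 2 to compound 3 (within the scatter) are both within the scatter, as is the step of no change at the digits printed from compound 1 to compound 2 (within the scatter). Three different aromatic groups at the same position of the shared core give the same maximal response.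

Compound 4 `O=C(O)Cc1sc(C(c2ccc(F)cc2)c2ccc(F)cc2)nc1-c1ccncc1` is not yet measured. It differs from compound 3 by pyridin-4-yl in place of furan-3-yl on an aromatic carbon. All three measured steps bear on this change, since each also exchanges the aromatic group at this position of the core, and none moved the maximal response beyond the scatter. A six-membered ring with a ring nitrogen has not been tried in this series, so the expectation rests on the pattern of the furan and difluorophenyl groups alone. No step beyond the scatter is expected for no change at the digits printed from compound 3 to compound 4 (within the scatter). For compound 4 the maximal response in this assay is estimated at 80%, with a range from 68% to 92%.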

Compound 4, largest response reached (reported as efficacy), in percent of the reference or control that the assay uses: 80%
Beside the measured number, compound 4's estimate shows no gap at the digits printed; measured number inside the range.
By their numbers in this assay, from the lowest: compounds 1, 2, 3 and 4 (each within the scatter of the next).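

In this assay the position next to the ring nitrogen also accepts pyridin-4-yl, a six-membered aromatic ring with a ring nitrogen, and the exchange for either furan leaves the maximal response level (no change at the digits printed from compound 3 to compound 4 (within the scatter)) and (no change at the digits printed from compound 2 to compound 4 (within the scatter)). Set against 3,5-difluorophenyl, the other six-membered aromatic ring at this position, pyridin-4-yl also brings no shift (no change at the digits printed from compound 1 to compound 4 (within the scatter)). Across these four compounds, neither ring size nor a ring oxygen or ring nitrogen separates the maximal responses in this read-out.

No available data explain why the response stays level across these groups. On these data alone, whether a non-aromatic group at this position, such as a piperidine ring, a primary amine or a longer alkyl chain, would keep the response level stays open.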